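Dechlorination of the aryl group in the enone series

A few compounds are considered here, and "the series" means these few. Any claim that something is new, unique, unknown or untested is made for them only; others in the source may bear on it.

Of the compounds shown here, two have been measured in a functional assay on RPMI8266 cells (Homo sapiens) for inhibition; a higher number here means a weaker inhibitor of growth, a lower number a stronger inhibitor of growth. Compound 1 `COc1cc(/C=C/C(=O)c2cccc(-n3cc(-c4ccc(Cl)cc4)[nH]c3=O)c2)cc(OC)c1OC` gives 3920 nM, the higher of the two numbers. Compound 2 `O=C(/C=C/c1cccc(O)c1)c1cccc(-n2cc(-c3ccc(Cl)cc3)[nH]c2=O)c1`, which carries a single hydroxy on the enone aryl ring in place of the three methoxy groups, gives 1550 nM; the gap between compound 1 and compound 2 is beyond the usual scatter, so compound 2 is the stronger inhibitor of growth of this pair. Among the compounds with values here, no direct one-place step between measured compounds is available.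

Compound 3 `COc1cc(/C=C/C(=O)c2cccc(-n3cc(-c4ccccc4)[nH]c3=O)c2)cc(OC)c1OC` keeps the trimethoxy enone and the shared core of compound 1 and differs only in hydrogen in place of chloro on an aromatic carbon. Within the data shown here, no measured analogue speaks to the effect of removing this halogen, so the expectation rests on the general observation that such a change usually shifts activity only modestly. The step from compound 1 to compound 3 in this assay is therefore expected to be small, at most a mild weakening and possibly within the scatter, a 1.3-fold higher number from compound 1 to compound 3 (0.11 log units; within the scatter). Compound 3 is estimated at 5000 nM, with a range from 2000 nM to 12000 nM.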

Compound 3, concentration for 50% growth inhibition: 620 nM
Compound 3: middle estimate off by 8.1-fold (0.91 log units), on the high side; measured number outside the range, below it.
By their numbers in this assay, from the lowest: compound 3; then compound 2; then compound 1.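

Hydrogen in place of chloro, the change from 4-chlorophenyl to phenyl, supplies the first one-place step in this series, and in this assay it is a clear gain in growth inhibition (a 6.3-fold lower number from compound 1 to compound 3 (0.80 log units; beyond the scatter)). With the trimethoxy enone and the shared core held constant, the chloro on this aromatic carbon, para to a large group, is therefore not required for activity, and its removal makes compound 3 the stronger inhibitor of growth of this pair. Nothing at hand explains why the loss of this single chlorine gives a step of this size.

Within the data shown here, it remains open whether the same change gives a step of similar size and direction with the single hydroxy of compound 2 on the enone aryl ring, since this step rests on one pair alone. Also open, on these data alone, is how a fluoro, a methyl, a methoxy or an amine on the same aromatic carbon would compare with hydrogen and chloro, and so whether the phenyl of compound 3 is the best option at this position.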